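From a Thiophene Alkyne to a Directly Attached Aryl Group

A few compounds are considered here, and "the series" means these few. Any claim that something is new, unique, unknown or untested is made for them only; others in the source may bear on it.

In a functional assay on NCI-H460 cells (Homo sapiens) for antiproliferative activity, with a stated time of 72 h (a lower number here means a stronger inhibitor, a higher number a weaker inhibitor), compound 1 (`CCCC#Cc1cc([C@@H]2O[C@H](CO)[C@@H](O)[C@H]2O)n2ncnc(N)c12`) gives 400 nM and compound 2 (`Nc1ncnn2c([C@@H]3O[C@H](CO)[C@@H](O)[C@H]3O)cc(C#Cc3cccs3)c12`) gives 26600 nM as the higher of the two numbers. Compound 3 (`Nc1ncnn2c([C@@H]3O[C@H](CO)[C@@H](O)[C@H]3O)cc(-c3ccc(F)cc3)c12`) differs from compound 2 by a single change (4-fluorophenyl in place of 2-(thiophen-2-yl)ethynyl on an aromatic carbon). For the measured compounds named here, the only measured step (a 67-fold higher number from compound 1 to compound 2 (1.82 log units; beyond the scatter)) is large and exchanges propyl for thiophen-2-yl on a triple-bonded carbon, but no measured step removes the triple bond. A moderate step toward a lower number is therefore expected (a 3.3-fold lower number from compound 2 to compound 3 (0.52 log units; beyond the scatter)) with wide uncertainty. In this assay compound 3 is estimated at 8000 nM (range 1000 nM to 50000 nM).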

Compound 3, half-maximal inhibitory concentration: 55500 nM
Estimate against measurement, compound 3: 6.9-fold (0.84 log units) below; the measured number lies above the stated range.
By their numbers in this assay, from the lowest: compound 1; then compound 2; then compound 3.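

In this assay, the directly attached 4-fluorophenyl group gives no lower number than the thiophene alkyne, with a 2.1-fold higher number from compound 2 to compound 3 (0.32 log units; beyond the scatter). Against the pent-1-yn-1-yl group, the same position shows a 140-fold higher number from compound 1 to compound 3 (2.14 log units; beyond the scatter), so both compounds carrying an aromatic ring in this substituent stand well above compound 1, with or without the triple bond. Nothing measured here bears on the cause of these steps. The compounds shown leave open whether a butyl chain attached directly to this carbon would stay near compound 1, and how an amine at the end of the alkyne chain would fare.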